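From Oxolan-3-yl to Methyl: Expected Clearance of Compound 3

The compounds below may be only part of what the source reports. "The series", "measured", "known", "first", "only" and "open" are said of these compounds alone.

Compound 2 `Cc1cc(C)c(CN2CCc3c(Cl)cc([C@@H](CO)[C@@H]4CCOC4)c(Cl)c3C2=O)c(=O)[nH]1` and compound 1 `Cc1cc(C)c(CN2CCc3c(Cl)cc([C@H](CO)[C@H]4CCOC4)c(Cl)c3C2=O)c(=O)[nH]1` are mirror images. In an ADME assay on microsomes from liver (Homo sapiens) for metabolic stability, read by LC-MS, using NADPH, with stated times of 10 min and 45 min, tested at 1 uM (on this read-out higher numbers stand for fast clearance and lower numbers for slow clearance), compound 1 gives 21.3 uL/min and compound 2 gives 25.3 uL/min. The step of a 1.2-fold higher number from compound 1 to compound 2 (0.07 log units; within the scatter) lies within the scatter, so compound 2 stands level with compound 1 on the two numbers shown. Compound 3 `Cc1cc(C)c(CN2CCc3c(Cl)cc([C@H](C)CO)c(Cl)c3C2=O)c(=O)[nH]1` differs from compound 2 by methyl in place of oxolan-3-yl on a saturated chain carbon bound to an aromatic carbon and a saturated chain carbon. Going by the values given here, the only measured step concerns configuration alone the fact that compounds 1 and 2 differ only in the configuration as drawn and offers no guide to a change of substituent. The step of a 1.1-fold lower number from compound 2 to compound 3 (0.04 log units; within the scatter) is therefore expected to stay within the scatter. Compound 3 is estimated at 23 uL/min, between 10 uL/min and 50 uL/min.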

Compound 3, intrinsic clearance in a liver preparation (reported as CLH), per the amount of preparation that the assay uses in the liver assay: 15.8 uL/min
Compound 3: middle estimate off by 1.5-fold (0.16 log units), on the high side; measured number inside the range.
By their numbers in the liver assay, from the lowest: compounds 3, 1 and 2 (each within the scatter of the next).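

Going by these compounds alone, in the liver assay, the first change of substituent at this saturated chain carbon leaves clearance within the scatter, with methyl in place of oxolan-3-yl giving a 1.6-fold lower number from compound 2 to compound 3 (0.20 log units; within the scatter), and the wider comparison giving a 1.3-fold lower number from compound 1 to compound 3 (0.13 log units; within the scatter). In a physicochemical assay for solubility, measured as kinetic solubility (a higher number here means a more soluble compound, a lower number a less soluble compound), compound 2 gives 537000 nM and compound 3 gives 131000 nM. This same change therefore separates the two compounds beyond the scatter on solubility, though not on clearance.

On these data alone, what an amine or a longer chain at this carbon would do in either assay remains open.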